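Removing a Methoxy from a Boronic Acid Stilbene

The source may hold more compounds than are shown below. What is called first, only, known or untested is meant among the compounds shown, and "the series" means these compounds.

Compound 1 `COc1ccc(/C=C\c2cc(OC)c(OC)c(OC)c2)cc1B(O)O` and compound 2 `COc1cc(/C=C\c2ccc(B(O)O)cc2)cc(OC)c1OC` are two stilbenes carrying a boronic acid that were tested in a functional assay on B16 cells (Mus musculus) for cytotoxicity; on this read-out higher numbers stand for weaker inhibition and lower numbers for stronger inhibition. Going by the values given here, compound 1 gives 6.3 nM, while compound 2 gives 2600 nM, the highest of the two numbers measured so far and far above the number for compound 1, a gap well beyond the scatter. Compound 3 `COc1cc(/C=C\c2ccc(B(O)O)cc2)cc(OC)c1` has not yet been measured. It differs from compound 2 in one place: hydrogen in place of methoxy on an aromatic carbon. Among the compounds with values here, nothing among the measured compounds shows what this kind of change does, so the expectation rests on compound 2 alone. Since compound 2 already gives 2600 nM, the step is expected to be modest and toward a higher number, with a 2.3-fold higher number from compound 2 to compound 3 (0.36 log units; beyond the scatter). Compound 3 is therefore estimated at 6000 nM, with a range from 1500 nM to 25000 nM.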

Compound 3, half-maximal inhibitory concentration: 12000 nM
The estimate for compound 3 lay 2.0-fold (0.30 log units) below the measured number; low and high end bracket the measured number.
By their numbers in this assay, from the lowest: compound 1; then compound 2; then compound 3.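

In this assay, replacing with hydrogen the methoxy that sits ortho to two methoxy groups gives a 4.6-fold higher number from compound 2 to compound 3 (0.66 log units; beyond the scatter), a step beyond the scatter. Going by these compounds alone, this is the first direct look at this change, and it shows that this methoxy matters: losing it goes with weaker inhibition, even though compound 2 was already weak and the two other methoxy groups remain in place. Nothing measured here explains why the number rises.

From the compounds shown here alone, whether a hydroxyl, a fluorine or an ethoxy at this place would hold the number of compound 2 or move it further remains open. Also open, going by these compounds, is whether the same loss of a methoxy would cost as much in the stilbene of compound 1, where inhibition is far stronger.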